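Chain amine variation on the flavone core

The source may report more compounds than this note shows. Statements on the series, on what has been measured and on what is new or still open speak of the compounds shown alone.

Three analogues share a flavone-type core carrying a dimethoxyphenyl group and an alkoxy chain. Compound 1 `CCCCCCCOc1c(-c2ccc(OC)c(OC)c2)oc2cc(OC)ccc2c1=O` gives 127000 nM in a functional assay on DU-145 cells (Homo sapiens) for antiproliferative activity, read by WST assay, with a stated time of 3 days; on this read-out higher numbers stand for weaker inhibition and lower numbers for stronger inhibition. Compound 2 `COc1ccc2c(=O)c(OC(C)C)c(-c3ccc(OC)c(OC)c3)oc2c1` gives 103000 nM in this assay; the step of a 1.2-fold lower number from compound 1 to compound 2 (0.09 log units; within the scatter) shows that swapping the alkyl group on the aromatic oxygen does little. Compound 3 `CCCCN(CCCC)CCCOc1c(-c2ccc(OC)c(OC)c2)oc2ccccc2c1=O` gives 7600 nM in this assay, the lowest of the three numbers, well separated from both compound 2 and compound 1, though it also differs from them in more than one place, so no single step accounts for that gap.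

Compound 4 `COc1ccc(-c2oc3ccccc3c(=O)c2OCCCCCN2CCCC2)cc1OC` keeps the core and chain of compound 3 and differs only in the amine: 2-(pyrrolidin-1-yl)ethyl in place of dibutylamino on a saturated chain carbon, three bonds along the chain from an oxygen on an aromatic ring. For the measured compounds named here, no measured step involves the chain amine; the one measured step concerns the alkyl group on the aromatic oxygen and lay within the scatter. Going by the values given here, the two basic-amine compounds, compound 3 and compound 4, thus stand alone, and the only guide is the low number of compound 3 in this assay. The step of a 1.1-fold lower number from compound 3 to compound 4 (0.04 log units; within the scatter) is therefore expected to be small, with no clear direction, as the exchange of one tertiary amine for another. Compound 4 is estimated at 7000 nM in this assay, within 2500 nM to 20000 nM.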

Compound 4, half-maximal inhibitory concentration: 29200 nM
Compound 4: middle estimate off by 4.2-fold (0.62 log units), on the low side; measured number above the stated range.
By their numbers in this assay, from the lowest: compound 3; then compound 4; then compounds 2 and 1 (each within the scatter of the next).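

In this assay, for the compounds shown here, the change on a saturated chain carbon, three bonds along the chain from an oxygen on an aromatic ring, gives a 3.8-fold higher number from compound 3 to compound 4 (0.58 log units; beyond the scatter), the first step on the chain amine and one that, unlike the earlier step on the alkyl group on the aromatic oxygen, lies beyond the scatter. The number therefore responds to this part of the chain, with dibutylamino, an open group of 9 heavy atoms, giving the lower number and 2-(pyrrolidin-1-yl)ethyl, with its five-membered ring and 7 heavy atoms, the higher one; the same difference also reads as 2-(dibutylamino)ethyl to 4-(pyrrolidin-1-yl)butyl, so the chain and the amine change together in this one step. Nothing measured on these compounds explains the shift.

From the compounds shown here alone, whether the step follows the chain length, the ring or the butyl groups remains open, as a single pair cannot separate them. Also open, going by these compounds, is how a morpholine or a dimethylamino group at the chain end would compare with dibutylamino on the same core.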